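Compound 2 to compound 4: a series at the assay limit

This account rests on a few compounds, and the source may have more. Where it says the series, first, only, none or still open, it means among the compounds named here.

In a functional assay on L02 cells (Homo sapiens) for inhibition, read by MTT assay, with a stated time of 48 h (a lower number here means a stronger inhibitor, a higher number a weaker inhibitor), compound 2 (`COc1cccc(NC(=O)/C=C/c2coc3cc(OC)ccc3c2=O)c1`) gives > 200000 nM which is a limit of the assay and not a number. Compound 1 (`O=C(/C=C/c1coc2cc(O)ccc2c1=O)NCc1ccccc1`) gives > 200000 nM which is likewise a limit. Compound 3 (`O=C(/C=C/c1coc2cc(O)ccc2c1=O)NCc1ccc(F)cc1`) gives > 200000 nM which is also a limit. Within the data shown here, the measured set comes down to the limit of > 200000 nM in this assay, at which 3 of the 3 values shown sit, and no compound yet has a readable number.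

Compound 4 (`COc1ccc2c(=O)c(/C=C/C(=O)NCc3ccc(C)cc3)coc2c1`) carries 4-methylbenzyl in place of 3-methoxyphenyl on an amide-type nitrogen. The counted difference is 4-methylbenzyl in place of 3-methoxyphenyl on an amide-type nitrogen and the remainder of compound 2 stays unchanged.

One measured step can be set against this change: a step that the two limits leave unreadable from compound 1 to compound 3 with fluoro in place of hydrogen on an aromatic carbon. Among the measured compounds shown here, it gives no size to carry over, and no measured step covers this exchange on the amide-type nitrogen. With nothing readable to suggest otherwise, no step beyond the scatter is expected in this assay and a further limit is the likely report.

For compound 4 the estimate is 200000 nM with an expected range of 100000 nM to 400000 nM in the same read-out. The expected a number no higher from compound 2 to compound 4 (the limit leaves the size open) is only an estimate made against a limit.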

Compound 4, half-maximal inhibitory concentration: > 200000 nM
Compound 4 ended at the assay's limit (the forecaster's own chance of this, stated with the estimate: 85%); the middle value lies on the limit itself.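

No size can be read for the step from compound 2 to compound 4 in this assay, since both values are limits of the assay and not numbers: the limit of > 200000 nM in this assay, at which 4 of the 4 values shown sit.

The compounds shown leave open whether any change on the amide-type nitrogen or elsewhere on the shared core would give a readable number in this assay at all.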